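This account rests on a few compounds, and the source may have more. Where it says the series, first, only, none or still open, it means among the compounds named here.

Series on the shared core. In a functional assay on SR cells (Homo sapiens) for cytotoxicity, read by sulforhodamine B assay, with a stated time of 48 h, tested at 100 uM (on this read-out higher numbers stand for a weaker effect at the one concentration tested and lower numbers for a stronger effect), compound 1 `COc1cc(-c2cc(/C=C/C(=O)c3ccc(N)cc3)[nH]n2)cc(OC)c1OC` gives -13% and compound 2 `COc1ccc(C(=O)/C=C/c2cc(-c3cc(OC)c(OC)c(OC)c3)n[nH]2)cc1OC` gives 3%, the higher of the two numbers, with the step of a number 16 percentage points higher from compound 1 to compound 2 (beyond the scatter) separating them. Compound 3 `COc1cc(C(=O)/C=C/c2cc(-c3cc(OC)c(OC)c(OC)c3)n[nH]2)cc(OC)c1OC` differs from compound 2 by methoxy in place of hydrogen on an aromatic carbon. Going by the values given here, no measured step touches a change of this kind; the one step in hand concerns a different part of the molecule, so no size can be read across. Compound 3 is therefore expected to stay near compound 2, with a number 2 percentage points higher from compound 2 to compound 3 (within the scatter) within the scatter, and is estimated at 5% in this assay, in the range -15% to 25%.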

Compound 3, a percentage reported as activity, at one concentration (the size of the read-out at that concentration, not a potency): 7%
Compound 3: the middle estimate sits 2 percentage points below what was measured, and the stated range covers the measured number.
By their numbers in this assay, from the lowest: compound 1; then compounds 2 and 3 (each within the scatter of the next).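

In this assay, methoxy in place of hydrogen on an aromatic carbon, ortho to a methoxy group and meta to a large group, gives a number 4 percentage points higher from compound 2 to compound 3 (within the scatter). Going by these compounds alone, at this position, the added methoxy therefore has no effect that can be told from the scatter, a first reading for this place on the molecule. Nothing at hand accounts for the result. Open, from the compounds shown here alone, is whether a group other than methoxy at this position, such as an amine, a hydroxy group or a longer ethoxy chain, would stay within the scatter too.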